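The source may hold more compounds than are shown below. What is called first, only, known or untested is meant among the compounds shown, and "the series" means these compounds.

Of the compounds shown here, three sharing one core have been tested in an ADME assay on HEK-293T cells (Homo sapiens) for cytotoxicity, read by MTT assay, with a stated time of 24 h (on this read-out lower numbers stand for higher toxicity in this test and higher numbers for lower toxicity in this test), and a fourth awaits its reading. Compound 1 `Cc1ccc(C(=O)n2c(-c3cn(-c4ccccc4)nc3-c3ccc(C(F)(F)F)cc3)nc3ccccc32)cc1` gives 169000 nM in this assay. Compound 2 `O=C(c1ccc(Cl)cc1)n1c(-c2cn(-c3ccccc3)nc2-c2ccc(C(F)(F)F)cc2)nc2ccccc21` gives 181000 nM in this assay, and compound 3 `Cc1ccc(-c2nn(-c3ccccc3)cc2-c2nc3ccccc3n2C(=O)c2ccc(Cl)cc2)cc1` gives 216000 nM in this assay. The three readings sit close together: between compound 2 and compound 1 the change is methyl in place of chloro on an aromatic carbon, and the step of a 1.1-fold lower number from compound 2 to compound 1 (0.03 log units; within the scatter). Between compound 2 and compound 3 the change is methyl in place of trifluoromethyl on an aromatic carbon, and the step of a 1.2-fold higher number from compound 2 to compound 3 (0.08 log units; within the scatter). None of these steps separates the compounds, so no order among them can be claimed.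

Compound 4 `Cc1ccc(C(=O)n2c(-c3cn(-c4ccccc4)nc3-c3ccc(C)cc3)nc3ccccc32)cc1` has not yet been measured in this assay. It differs from compound 3 by methyl in place of chloro on an aromatic carbon, the same change that turns compound 2 into compound 1, made at the same place. That earlier step, a 1.1-fold lower number from compound 2 to compound 1 (0.03 log units; within the scatter), stayed within the scatter, and a step of similar size is expected here, a 1.1-fold lower number from compound 3 to compound 4 (0.03 log units; within the scatter), resting on that single precedent and on the closeness of all three measured values. The estimate for compound 4 in this assay is therefore 200000 nM, with a range from 120000 nM to 330000 nM, since the only support is one matched pair within the scatter and the readings lie at the high end where a limit may be reported instead.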

Compound 4, half-maximal cytotoxic concentration: 176000 nM
Beside the measured number, compound 4's estimate is 1.1-fold (0.06 log units) above it; low and high end bracket the measured number.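

In this assay, the two changes can now each be read on two cores. Methyl in place of chloro, seen here as a 1.2-fold lower number from compound 3 to compound 4 (0.09 log units; within the scatter), carries from one core to the other without a difference that can be told apart: the same change on two cores in this assay, a 1.1-fold lower number (0.03 log units; within the scatter) from compound 2 to compound 1 and a 1.2-fold lower number (0.09 log units; within the scatter) from compound 3 to compound 4, 1.1-fold (0.06 log units) apart, within the scatter of two such steps. Methyl in place of trifluoromethyl, seen here as a 1.0-fold higher number from compound 1 to compound 4 (0.02 log units; within the scatter), behaves likewise, but with every step inside the scatter this shows only that neither change moved the reading on these two cores, not that either has a small, reproducible effect that transfers: the same change on two cores in this assay, a 1.2-fold higher number (0.08 log units; within the scatter) from compound 2 to compound 3 and a 1.0-fold higher number (0.02 log units; within the scatter) from compound 1 to compound 4, 1.1-fold (0.06 log units) apart, within the scatter of two such steps.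

From the compounds shown here alone, the four compounds carry only methyl, chloro or trifluoromethyl at the two places that vary, so it remains open whether an amine, a carboxylic acid or a longer chain at either place would leave the reading just as unmoved. Also open, going by these compounds, is whether the same two changes would stay this quiet on a core whose reading lies much lower in this test, where a shift would be easier to tell from the scatter.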